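The source may report more compounds than this note shows. Statements on the series, on what has been measured and on what is new or still open speak of the compounds shown alone.

Three compounds were measured in a functional assay on NCI-H1975 cells (Homo sapiens) for antiproliferative activity, read by MTT assay, with a stated time of 72 h; a lower number here means a stronger inhibitor, a higher number a weaker inhibitor:

compound 1 `COc1cc2ncnc(Nc3ccc(F)c(Cl)c3)c2cc1OCCCCC(=O)Nc1ccc(S(N)(=O)=O)cc1` gives 35600 nM
compound 2 `COc1cc2ncnc(Nc3cccc(Br)c3)c2cc1OCCCCC(=O)Nc1ccc(S(N)(=O)=O)cc1` gives 11400 nM
compound 3 `COc1cc2ncnc(Nc3ccc(OC(F)(F)F)cc3)c2cc1OCCCCC(=O)Nc1ccc(S(N)(=O)=O)cc1` gives 8770 nM

All three share the same core and side chain and differ only in the group carried on the nitrogen. Compound 3 has the lowest number of the three: the step of a 4.1-fold lower number from compound 1 to compound 3 (0.61 log units; beyond the scatter) is beyond the scatter, whereas the step of a 1.3-fold lower number from compound 2 to compound 3 (0.11 log units; within the scatter) is within it, so compound 2 and compound 3 cannot be ranked against each other. Compound 4 `COc1cc2ncnc(Nc3ccc(C)cc3)c2cc1OCCCCC(=O)Nc1ccc(S(N)(=O)=O)cc1` has not yet been measured; the change from compound 3 is methyl in place of trifluoromethoxy on an aromatic carbon. For the measured compounds named here, no measured step swaps a trifluoromethoxy for a methyl, so none bears on it directly. The steps that alter the same group, a 3.1-fold lower number from compound 1 to compound 2 (0.49 log units; beyond the scatter) and a 4.1-fold lower number from compound 1 to compound 3 (0.61 log units; beyond the scatter), were modest, and the exchange between two of these groups, a 1.3-fold lower number from compound 2 to compound 3 (0.11 log units; within the scatter), stayed within the scatter. A small step is therefore expected here, with a somewhat higher number judged a little more likely, estimated as a 1.4-fold higher number from compound 3 to compound 4 (0.14 log units; within the scatter). Compound 4 is expected to give about 12000 nM in this assay, within a range from 5000 nM to 30000 nM.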

Compound 4, half-maximal inhibitory concentration: 19300 nM
For compound 4 the middle estimate is 1.6-fold (0.21 log units) below the measured one; measured number inside the range.
By their numbers in this assay, from the lowest: compounds 3, 2, 4 and 1 (each within the scatter of the next, the first and the last beyond it).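

For the compounds shown here, compound 3 and compound 4 differ only in the group para to a large group on the same six-membered aromatic ring, so this pair isolates that position, whereas the earlier steps exchanged the whole group on the nitrogen. In this assay, methyl in place of trifluoromethoxy gives a 2.2-fold higher number from compound 3 to compound 4 (0.34 log units; beyond the scatter), showing that this single change has a modest effect that can be told apart from the scatter. The other two comparisons, a 1.7-fold higher number from compound 2 to compound 4 (0.23 log units; within the scatter) and a 1.8-fold lower number from compound 1 to compound 4 (0.27 log units; within the scatter), do not separate compound 4 from compound 2 or compound 1, and no measurement here accounts for the effect of the methyl-for-trifluoromethoxy change.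

The compounds shown leave open how an amine, a carboxylic acid or a longer alkyl chain would behave at this position. They also leave open whether any group there could give a much lower number than compound 3 at 8770 nM.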